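The source may hold more compounds than are shown below. What is called first, only, known or untested is meant among the compounds shown, and "the series" means these compounds.

Compound 1 `CC(O)(CSc1ccccc1OC(F)(F)F)C(=O)Nc1ccc(S(F)(F)(F)(F)F)cc1`: 15000 nM
Compound 2 `CC(O)(CSc1ccc(C(F)(F)F)cc1)C(=O)Nc1cccc(S(F)(F)(F)(F)F)c1`: 26900 nM
Compound 3 `CC(O)(COc1cccc(S(F)(F)(F)(F)F)c1)C(=O)Nc1cccc(S(F)(F)(F)(F)F)c1`: 27300 nM

These three values come from a functional assay on CWR22R cells (Homo sapiens) for antiproliferative activity, read by propidium iodide staining, with a stated time of 96 h; a higher number here means a weaker inhibitor, a lower number a stronger inhibitor. Compound 3 gives 27300 nM, which lies within the usual scatter of the values of both other compounds, so the three cannot be told apart in this test.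

Compound 4 `CC(O)(COc1cccc(OC(F)(F)F)c1)C(=O)Nc1cccc(S(F)(F)(F)(F)F)c1` keeps the rest of compound 3 and changes one place: a group of 5 heavy atoms (1 carbon, 1 oxygen, 3 fluorine; no ring) in place of a group of 6 heavy atoms (5 fluorine, 1 sulfur; no ring), on an aromatic carbon. The entering group is trifluoromethoxy, and it sits on an aromatic carbon, meta to a large group.

Going by the values given here, no two measured compounds differ in only one place, so the data give no direct guide to this change. Compound 1 carries a trifluoromethoxy group and gives 15000 nM, a value that does not stand apart from the others. In this assay, a step no larger than the scatter is therefore expected. The estimated step is a 1.1-fold lower number from compound 3 to compound 4 (0.06 log units; within the scatter). Compound 4 is estimated at 24000 nM, with an expected range from 11000 nM to 50000 nM.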

Compound 4, half-maximal inhibitory concentration: 18800 nM
The estimate for compound 4 lay 1.3-fold (0.11 log units) above the measured number, and the stated range covers the measured number.
By their numbers in this assay, from the lowest: compounds 1, 4, 2 and 3 (each within the scatter of the next).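

Going by these compounds alone, this is the first pair in the set that differs in only one place, so the exchange of the group of 5 fluorine and 1 sulfur for trifluoromethoxy, on an aromatic carbon meta to a large group, can now be read directly. In this assay the exchange gives a 1.5-fold lower number from compound 3 to compound 4 (0.16 log units; within the scatter), so the two groups cannot be told apart at this position, even though the entering group counts 1 hydrogen-bond acceptor and the leaving group none. Nothing measured here offers an explanation for this result.

As far as these compounds go, how a quite different group at this position, such as an amine or a carboxylic acid, would compare remains open. So does whether the same exchange would give a similar result with a sulfur atom in the linking chain, as in compound 2.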